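Ester variants on a glycoside core: antiproliferative notes

The source may hold more compounds than are shown below. What is called first, only, known or untested is meant among the compounds shown, and "the series" means these compounds.

Measured compounds:
Compound 1 `C/C=C1/[C@H](O[C@@H]2O[C@H](CO)[C@@H](O)[C@H](O)[C@H]2O)OC=C(C(=O)OC)[C@H]1CC(=O)O` gives > 15000 nM in a functional assay on SK-BR-3 cells (Homo sapiens) for antiproliferative activity, read by MTT assay, with a stated time of 72 h; a lower number here means a stronger inhibitor, a higher number a weaker inhibitor; this is a limit of the assay.
Compound 2 `C/C=C1/[C@H](O[C@@H]2O[C@H](CO)[C@@H](O)[C@H](O)[C@H]2O)OC=C(C(=O)OC)[C@H]1CC(=O)OCCc1ccc(OC)cc1` gives > 20000 nM in this assay; this is a limit.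
Compound 3 `C/C=C1/[C@H](O[C@@H]2O[C@H](CO)[C@@H](O)[C@H](O)[C@H]2O)OC=C(C(=O)OC)[C@H]1CC(=O)OCc1ccc(OC)c(OC)c1` gives > 15000 nM in this assay; this too is a limit.

Compound 3 thus stands only at a limit, and the other two values shown are limits as well, as the limit of > 15000 nM in this assay, at which 2 of the 3 values shown sit, and the limit of > 20000 nM in this assay, at which 1 of the 3 values shown sits, record. Consequently the steps a step that the two limits leave unreadable from compound 1 to compound 2, a step that the two limits leave unreadable from compound 1 to compound 3 and a step that the two limits leave unreadable from compound 2 to compound 3 are all unreadable; none of them gives a size or a direction.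

The step in question leads to compound 4 `C/C=C1/[C@H](O[C@@H]2O[C@H](CO)[C@@H](O)[C@H](O)[C@H]2O)OC=C(C(=O)OC)[C@H]1CC(=O)OCc1ccco1`: furan-2-yl in place of 3,4-dimethoxyphenyl on a saturated chain carbon bound to an oxygen next to a carbonyl group. The replacement of the ester alcohol part by another aryl-methyl group has so far never moved a value off the limit, across compound 1, compound 2 and compound 3. Among the measured compounds shown here, no measured step bears readably on the change, so no step beyond the scatter is expected, and the value is expected to remain at or near the limit. Compound 4 is estimated at 20000 nM, with a range from 8000 nM to 60000 nM, most likely reported only as a limit. The expected step is a step that the limit leaves unreadable from compound 3 to compound 4.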

Compound 4, half-maximal inhibitory concentration: > 15000 nM
Compound 4 gave a limit, no number; the forecaster's own chance of this, stated with the estimate: 85%; the middle value is on the limit's open side.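

In this assay, among the compounds shown here, compound 4 gives > 15000 nM, which is a limit, so no step to compound 4 from compound 1, compound 2 or compound 3 can be read. The compounds shown leave open whether any ester alcohol part on the shared core changes the value in this assay.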